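Trifluoromethyl in place of methyl, tolerated at the limit

This account rests on a few compounds, and the source may have more. Where it says the series, first, only, none or still open, it means among the compounds named here.

In an ADME assay on HepG2 cells (Homo sapiens) for cytotoxicity, read by MTT assay, with a stated time of 72 h (a higher number here means that more compound is tolerated, a lower number that less compound is tolerated), compound 1 `O=[N+]([O-])c1c(CS(=O)(=O)c2ccccc2)nc2c(Br)cc(C(F)(F)F)cn12` gives > 15600 nM, which is a limit. Compound 2 `Cc1cc(Sc2ccc(Cl)cc2)c2nc(CS(=O)(=O)c3ccccc3)c([N+](=O)[O-])n2c1` gives > 62500 nM, also a limit, so compound 2 has no exact number. Compound 3 `O=[N+]([O-])c1c(CS(=O)(=O)c2ccccc2)nc2c(Sc3ccc(Cl)cc3)cc(C(F)(F)F)cn12` differs from compound 2 in one place: trifluoromethyl in place of methyl on an aromatic carbon, with trifluoromethyl in place of methyl on an aromatic carbon. Going by the values given here, no measured step covers this change. In this assay, the expected change is small, toward lower tolerated concentrations and hardly beyond the scatter, with an estimated step of an at least 2.0-fold lower number from compound 2 to compound 3 (0.30 log units; that floor lies within the scatter). Compound 3 is expected at 31000 nM, with an estimated range of 8000 nM to 90000 nM.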

Compound 3, half-maximal cytotoxic concentration: > 7800 nM
Compound 3 gave a limit, no number; the forecaster's own chance of this, stated with the estimate: 75%; the middle value lies beyond the limit too.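

All three values are limits, so neither the step from compound 2 to compound 3 nor the step from compound 1 to compound 3 can be read. As far as these compounds go, whether either exchange changes the tolerated concentration stays open.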